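Three amides at the assay ceiling and one newcomer

This account rests on a few compounds, and the source may have more. Where it says the series, first, only, none or still open, it means among the compounds named here.

Compound 1 `COc1ccc(OC)c(NC(=O)c2cc(=O)[nH]c3cc(Br)ccc23)c1` was tested in a functional assay on KYSE-70 cells for antiproliferative activity against KYSE-70 cell line (Homo sapiens), read by MTT assay, with a stated time of 72 h (on this read-out higher numbers stand for weaker inhibition and lower numbers for stronger inhibition), where compound 1 gives > 20000 nM, which is a limit of the assay and not a number. Compound 2 `O=C(Nc1cccc(C(F)(F)F)c1)c1cc(=O)[nH]c2cc(Br)ccc12` in this assay likewise gives > 20000 nM, again a limit rather than a measured value. Compound 3 `O=C(Nc1cccc(F)c1)c1cc(=O)[nH]c2cc(-c3ccccc3)ccc12` in this assay gives > 20000 nM, also a limit. Compound 3 therefore stands nowhere in particular among the numbers shown: all three values sit at the limit of > 20000 nM in this assay, at which 3 of the 3 values shown sit, so no compound can be set above or below another, and no step between measured compounds can be read from them.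

Compound 4 `O=C(Nc1cccc(F)c1)c1cc(=O)[nH]c2cc(-c3ccc(F)c(CO)c3)ccc12` is the next compound to be measured in this assay. It differs from compound 3 by 4-fluoro-3-(hydroxymethyl)phenyl in place of phenyl on an aromatic carbon. Going by the values given here, nothing in the measured compounds tells how such a change moves the read-out, since every value so far is a limit. The step expected from compound 3 to compound 4 an at least 1.1-fold lower number from compound 3 to compound 4 (0.04 log units; that floor lies within the scatter) is therefore none beyond the scatter, with the limit itself the most likely outcome. Compound 4 is expected to give 18000 nM in this assay, in a range from 4000 nM to 40000 nM.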

Compound 4, half-maximal inhibitory concentration: > 20000 nM
Compound 4: a limit, no number; the forecaster's own chance of this, stated with the estimate: 65%; at least 1.1-fold (0.04 log units) between middle value and limit.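

In this assay compound 4 gives > 20000 nM as a limit of the assay and not a number. Going by these compounds alone, no step from compound 3 to compound 4 can be read, since both values are limits: the limit of > 20000 nM in this assay, at which 4 of the 4 values shown sit. The compounds shown leave open whether any change on the shared core would bring a value within the range of the assay.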